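The source may hold more compounds than are shown below. What is called first, only, known or untested is meant among the compounds shown, and "the series" means these compounds.

Compound 1 `COc1cc(/C=C2\CN(C)C/C(=C\c3ccc(Br)cc3)C2=O)cc(OC)c1OC`: 5330 nM
Compound 2 `COc1cc(/C=C2\CN(C)C/C(=C\c3ccc(Cl)cc3Cl)C2=O)cc(OC)c1OC`: 5020 nM

In a functional assay on THP-1 cells (Homo sapiens) for cytotoxicity, read by MTT assay, with a stated time of 24 h (a higher number here means a weaker inhibitor, a lower number a stronger inhibitor), compound 2 gives 5020 nM, which is within the scatter of compound 1 at 5330 nM. The two measured compounds therefore cannot be separated on these numbers.

Compound 3 `COc1cc(/C=C2\CN(C)C/C(=C\c3ccc(Cl)c(Cl)c3)C2=O)cc(OC)c1OC` has the same atoms as compound 2, joined differently: 3,4-dichlorophenyl in place of 2,4-dichlorophenyl on a double-bonded chain carbon bound to a double-bonded ring carbon. It carries 3,4-dichlorophenyl in place of 2,4-dichlorophenyl on a double-bonded chain carbon bound to a double-bonded ring carbon.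

Within the data shown here, one measured step bears on this change, at the same place: a 1.1-fold lower number from compound 1 to compound 2 (0.03 log units; within the scatter). Among the measured compounds shown here, no measured compound yet carries 3,4-dichlorophenyl, so this evidence is thin. On this single step, no shift beyond the scatter is expected in either direction in this assay. The estimated step is a 1.0-fold lower number from compound 2 to compound 3 (0.00 log units; within the scatter). For compound 3 the estimate is 5000 nM, with an expected range of 2500 nM to 10000 nM.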

Compound 3, half-maximal inhibitory concentration: 5330 nM
Compound 3: the middle estimate sits 1.1-fold (0.03 log units) below what was measured; low and high end bracket the measured number.
By their numbers in this assay, from the lowest: compounds 2, 1 and 3 (each within the scatter of the next).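

In this assay, among these compounds, the new compound shows for the first time that the same atoms can be joined differently at this place: 3,4-dichlorophenyl in place of 2,4-dichlorophenyl gives a 1.1-fold higher number from compound 2 to compound 3 (0.03 log units; within the scatter). Set against 4-bromophenyl, the same group gives no change at the digits printed from compound 1 to compound 3 (within the scatter), so the three groups on a double-bonded chain carbon bound to a double-bonded ring carbon cannot be separated on these numbers. Nothing available offers an explanation for this result.

From the compounds shown here alone, all three compounds carry a halogen-bearing phenyl at this place, so it stays open whether an amine or a carboxylic acid on that ring would leave the number within the scatter. Going by these compounds, the rest of the shared core is identical in all three, so what a change there would do also stays open.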